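The source may report more compounds than this note shows. Statements on the series, on what has been measured and on what is new or still open speak of the compounds shown alone.

Compound 1 `O=c1nc(N2CCN(NC3CCCCC3)CC2)sc2c([N+](=O)[O-])cc(C(F)(F)F)cc12` gives > 64 ug/mL in an ADME assay on Vero cells (Chlorocebus sabaeus) for cytotoxicity, read by MTT assay, with a stated time of 72 h (a lower number here means that less compound is tolerated, a higher number that more compound is tolerated), which is a limit of the assay rather than a number. Compound 2 `COc1ccc(CNN2CCN(c3nc(=O)c4cc(C(F)(F)F)cc([N+](=O)[O-])c4s3)CC2)cc1` gives > 64 ug/mL in this assay, likewise a limit. Compound 3 `CC(C)(C)c1ccc(CNN2CCN(c3nc(=O)c4cc(C(F)(F)F)cc([N+](=O)[O-])c4s3)CC2)cc1` gives > 64 ug/mL in this assay, likewise a limit.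

Compound 1 thus stands only at a limit in this assay, as the limit of > 64 ug/mL in this assay, at which 3 of the 3 values shown sit, shows. Compound 4 `O=c1nc(N2CCN(Nc3ccc(C(F)(F)F)cc3)CC2)sc2c([N+](=O)[O-])cc(C(F)(F)F)cc12` differs from compound 1 in one place: 4-(trifluoromethyl)phenyl in place of cyclohexyl on an amine nitrogen. The two measured steps that touch the same amine nitrogen, a step that the two limits leave unreadable from compound 1 to compound 2 and a step that the two limits leave unreadable from compound 1 to compound 3, are of unreadable size; both of their ends sit at the limit. No direction can be read from them, and no step beyond the scatter is expected for compound 4. Compound 4 is expected to give 64 ug/mL, within 32 ug/mL to 128 ug/mL, an expected step of a number no higher from compound 1 to compound 4 (the limit leaves the size open).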

Compound 4, half-maximal cytotoxic concentration: > 64 ug/mL
Compound 4 ended at the assay's limit; the forecaster's own chance of this, stated with the estimate: 75%; the middle value lies on the limit itself.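

No step can be read between compound 1, compound 2, compound 3 and compound 4 in this assay, since all sit at one limit: the limit of > 64 ug/mL in this assay, at which 4 of the 4 values shown sit. The compounds shown leave open where each true half-maximal cytotoxic concentration lies, and whether the group on the amine nitrogen affects it.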